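The compounds below may be only part of what the source reports. "The series", "measured", "known", "first", "only" and "open" are said of these compounds alone.

Compound 3, `COC(=N)c1cn(COCCO)c2ncnc(N)c12`, stands with the other two members of this small set at the edge of what the assay can report: in an ADME assay on BSC-1 cells (Cercopithecidae) for cytotoxicity (on this read-out higher numbers stand for weaker inhibition and lower numbers for stronger inhibition), compound 3 gives > 100000 nM, which is a limit of the assay rather than a number. Compound 1, `Nc1ncnc2c1ccn2COCCO`, gives > 100000 nM in this assay, again a limit. Compound 2, `N#Cc1cn(COCCO)c2ncnc(N)c12`, gives > 320000 nM in this assay, also a limit. Two of the three values thus sit at the limit of > 100000 nM in this assay, at which 2 of the 3 values shown sit, and one at the limit of > 320000 nM in this assay, at which 1 of the 3 values shown sits, and no compound in the set has shown a measurable inhibition of these cells. The step from compound 3 to compound 4, `NC(=S)c1cn(COCCO)c2ncnc(N)c12`, is a group of 3 heavy atoms (1 carbon, 1 nitrogen, 1 sulfur; no ring) in place of a group of 4 heavy atoms (2 carbon, 1 nitrogen, 1 oxygen; no ring), on an aromatic carbon. The measured steps that bear on this position are a step that the two limits leave unreadable from compound 1 to compound 2, a step that the two limits leave unreadable from compound 1 to compound 3 and a step that the two limits leave unreadable from compound 2 to compound 3; each runs between limits, and none yields a readable size or direction. Nothing in the set points to any cytotoxicity appearing at this position. For compound 4 the expected step in this assay is a step that the limit leaves unreadable from compound 3 to compound 4, nothing beyond the scatter. Compound 4 is therefore estimated at 150000 nM in this assay, within a range from 50000 nM to 500000 nM, and is expected to be reported again only as a limit.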

Compound 4, half-maximal inhibitory concentration: > 100000 nM
Compound 4 was reported as a limit; the forecaster's own chance of this, stated with the estimate: 85%; the middle value does not contradict the limit.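

In this assay compound 4 gives > 100000 nM, which is again a limit of the assay and not a number. None of the steps from compound 1, compound 2 or compound 3 to compound 4 can be read. The compounds shown leave open at what concentration, if any, each of the four would inhibit these cells, and how the groups on this aromatic carbon compare.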